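The compounds below may be only part of what the source reports. "The series", "measured", "known", "first", "only" and "open" are said of these compounds alone.

Working notes on the series. Among the compounds with values here, compound 1, `CN(C)C(=O)c1cc2cnc(Nc3ccc(C(=O)NCCCCN=C=S)cc3)nc2n1C1CCCC1`, gives the higher of the two numbers so far in a functional assay on A549 cells (Homo sapiens) for inhibition, read by CCK-8 assay, with a stated time of 72 h, tested at 10 uM (on this read-out higher numbers stand for a stronger effect at the one concentration tested and lower numbers for a weaker effect), where compound 1 reads 102%; the gap to its nearest neighbour lies within the scatter. That neighbour is compound 2, `CN(C)C(=O)c1cc2cnc(Nc3ccc(C(=O)NCCCCCCN=C=S)cc3)nc2n1C1CCCC1`, which in this assay reads 100%. Within the data shown here, the one measured step, a number 2 percentage points lower from compound 1 to compound 2 (within the scatter), puts a group of 5 heavy atoms in place of a group of 3 heavy atoms on a saturated chain carbon, four bonds along the chain from an amide-type nitrogen, and leaves the read-out unchanged beyond the scatter.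

The next compound, compound 3, `CN(C)C(=O)c1cc2cnc(Nc3ccc(C(=O)NCCCCN=C=S)cc3F)nc2n1C1CCCC1`, differs from compound 1 as follows: fluoro in place of hydrogen on an aromatic carbon. Among the measured compounds shown here, no measured step touches the six-membered aromatic ring of carbon only, so the chain step is the only guide; it shows the series holding a full read-out in this assay under a change elsewhere. On that basis no step beyond the scatter is expected, so the step expected is a number 4 percentage points lower from compound 1 to compound 3 (within the scatter). Compound 3 is therefore estimated at 98%, with a range from 85% to 105%.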

Compound 3, a percentage reported as inhibition, at one concentration (the size of the read-out at that concentration, not a potency): 24.4%
Estimate against measurement, compound 3: 73.6 percentage points above, and the stated range ends above it.
By their numbers in this assay, from the lowest: compound 3; then compounds 2 and 1 (each within the scatter of the next).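

The six-membered aromatic ring of carbon only proves sensitive where the chain was not: in this assay, fluoro in place of hydrogen on an aromatic carbon, ortho to a large group and meta to a large group, gives a number 77.6 percentage points lower from compound 1 to compound 3 (beyond the scatter). This replacement adds only one heavy atom, yet its step is beyond the scatter, whereas the larger change on the chain gives a number 2 percentage points lower from compound 1 to compound 2 (within the scatter), so the read-out at this concentration depends on this ring position far more than the two chain compounds could show. Nothing measured on these compounds bears on why the read-out falls with this change.

The compounds shown do not settle whether the drop belongs to fluoro itself or would also follow from another group at this carbon, such as chloro, methyl or methoxy, or from fluoro on another carbon of the ring. They also leave open whether fluoro at this position would give a similar step on the longer chain of compound 2, whose value stands level with that of compound 1 within the scatter.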